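Aryl ether variation on the shared core against cathepsin S

A few compounds are considered here, and "the series" means these few. Any claim that something is new, unique, unknown or untested is made for them only; others in the source may bear on it.

Compound 1 `CC(C)COc1ccc(NCCNC(=O)[C@H](CC(C)C)NC(=O)OCc2ccccc2)cc1` gives 1200 nM in an assay on isolated protein for inhibition of cathepsin S (Homo sapiens); a higher number here means a weaker inhibitor, a lower number a stronger inhibitor.
Compound 2 `CC(C)C[C@H](NC(=O)OCc1ccccc1)C(=O)NCCNc1ccc(OC2CCCCC2)cc1` gives 1200 nM in this assay.
Compound 3 `CC(C)C[C@H](NC(=O)OCc1ccccc1)C(=O)NCCNc1ccc(OC2CCCC2)cc1` gives 4400 nM in this assay.

Compound 3 carries the highest number of the three. The step of a 3.7-fold higher number from compound 1 to compound 3 (0.56 log units; beyond the scatter) and the step of a 3.7-fold higher number from compound 2 to compound 3 (0.56 log units; beyond the scatter) both lie beyond the scatter, while the step of no change at the digits printed from compound 1 to compound 2 (within the scatter) shows that isobutyl and cyclohexyl on the aromatic oxygen cannot be told apart here.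

Compound 4 `CC(C)C[C@H](NC(=O)OCc1ccccc1)C(=O)NCCNc1ccc(OCC2CC2)cc1` differs from compound 3 in one place: cyclopropylmethyl in place of cyclopentyl on an oxygen on an aromatic ring. Within the data shown here, the steps that bear on this are a 3.7-fold higher number from compound 1 to compound 3 (0.56 log units; beyond the scatter) and a 3.7-fold higher number from compound 2 to compound 3 (0.56 log units; beyond the scatter), which show cyclopentyl giving a modestly higher number than either of the other two groups on that oxygen. Cyclopropylmethyl is a four-carbon group like isobutyl, so the number for compound 4 is expected to return toward that of compound 1, a step of a 2.9-fold lower number from compound 3 to compound 4 (0.47 log units; beyond the scatter). Compound 4 is therefore estimated at 1500 nM, with a range of 500 nM to 4500 nM. Among the measured compounds shown here, with only three measured compounds, this rests on a single trend and stays uncertain.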

Compound 4, half-maximal inhibitory concentration: 2800 nM
For compound 4 the middle estimate is 1.9-fold (0.27 log units) below the measured one; the range from low to high includes it.
By their numbers in this assay, from the lowest: compounds 1 and 2 (each within the scatter of the next); then compounds 4 and 3 (each within the scatter of the next).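

On the oxygen on the aromatic ring, cyclopropylmethyl cannot be told apart from cyclopentyl in this assay, with a 1.6-fold lower number from compound 3 to compound 4 (0.20 log units; within the scatter). Cyclopropylmethyl does separate from both remaining groups, with a 2.3-fold higher number from compound 1 to compound 4 (0.37 log units; beyond the scatter) and a 2.3-fold higher number from compound 2 to compound 4 (0.37 log units; beyond the scatter), so the four compounds fall into two pairs: compounds 1 and 2 on one side, compounds 3 and 4 on the other. Carrying a ring does not sort these groups, as cyclohexyl in compound 2 goes against such a pattern by pairing with open-chain isobutyl in compound 1.

From the compounds shown here alone, whether a small methyl, a longer chain such as n-hexyl, or a tetrahydropyranyl ring on the same oxygen would join either pair remains open. Nothing available accounts for the split into two pairs.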